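Compound 3 to compound 4: cyclopentyl to 1-methylcyclopropyl

The source may report more compounds than this note shows. Statements on the series, on what has been measured and on what is new or still open speak of the compounds shown alone.

Measured so far in a functional assay on the whole organism with Rattus norvegicus as the target; on this read-out higher numbers stand for an effect only at larger amounts of compound and lower numbers for an effect already at smaller amounts:
- compound 1 `COC(=O)CC/C=C\CC[C@H]1C(=O)C[C@@H](O)[C@@H]1/C=C/CC(C)(O)CCC1CC1`: 0.273 mg/kg
- compound 2 `COC(=O)CC/C=C\CC[C@H]1C(=O)C[C@@H](O)[C@@H]1/C=C/C[C@@](C)(O)C#CC1=CCCC1`: > 3.16 mg/kg (a limit)
- compound 3 `COC(=O)CC/C=C\CC[C@H]1C(=O)C[C@@H](O)[C@@H]1/C=C/C[C@@](C)(O)/C=C/C1CCCC1`: 1.95 mg/kg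

Of the two true numbers, compound 3 at 1.95 mg/kg holds the higher, and compound 1 at 0.273 mg/kg is its nearest neighbour. The result for compound 2 is a limit, > 3.16 mg/kg. Measured against that limit, the change is an at least 1.6-fold lower number from compound 2 to compound 3 (0.20 log units; that floor lies within the scatter).

Compound 4 `COC(=O)CC/C=C\CC[C@H]1C(=O)C[C@@H](O)[C@@H]1/C=C/C[C@@](C)(O)/C=C/C1(C)CC1` differs from compound 3 in one group: 1-methylcyclopropyl in place of cyclopentyl on a double-bonded chain carbon bound to a double-bonded chain carbon. In words, 1-methylcyclopropyl stands in place of cyclopentyl on a double-bonded chain carbon bound to a double-bonded chain carbon.

Within the data shown here, no measured step isolates this swap. The closest guide is a 7.1-fold higher number from compound 1 to compound 3 (0.85 log units; beyond the scatter), where compound 1 carries a cyclopropyl ring but also a saturated chain, so that step mixes two changes. The step of an at least 11-fold higher number from compound 1 to compound 2 (1.06 log units; beyond the scatter) shows that this end of the molecule can move the number widely. Only part of the gap to compound 1 is expected to carry over, pointing to a small move toward a lower number in this assay. The expected step is a 2.4-fold lower number from compound 3 to compound 4 (0.39 log units; beyond the scatter). Compound 4 is estimated at 0.8 mg/kg, with an expected range of 0.3 mg/kg to 2.6 mg/kg.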

Compound 4, dose for half-maximal effect: 1.34 mg/kg
For compound 4 the middle estimate is 1.7-fold (0.22 log units) below the measured one; the measured number falls inside the stated range.
By their numbers in this assay, from the lowest: compound 1; then compounds 4 and 3 (each within the scatter of the next). At a limit, above all of these: compound 2.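

In this assay, 1-methylcyclopropyl in place of cyclopentyl on a double-bonded chain carbon gives a 1.5-fold lower number from compound 3 to compound 4 (0.16 log units; within the scatter), so the compounds shown do not separate these two ring groups at this position. The gap to the saturated chain remains with a three-membered ring on both sides, a 4.9-fold higher number from compound 1 to compound 4 (0.69 log units; beyond the scatter), so a three-membered ring at the chain end does not by itself bring the number to that of compound 1. The 2-(1-methylcyclopropyl)ethenyl group also stands apart from 2-(cyclopent-1-en-1-yl)ethynyl, an at least 2.3-fold lower number from compound 2 to compound 4 (0.37 log units; beyond the scatter), though this step rests on a limit and not on a true number: the limit of > 3.16 mg/kg in this assay, at which 1 of the 4 values shown sits.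

Still open is whether the remaining gap to compound 1 follows the saturated chain or the methyl on the ring, as the compounds shown change both together. As far as these compounds go, the effect of a plain cyclopropyl on the ethenyl chain, a cyclopentyl on the saturated chain, or a phenyl at the chain end also remains open in this assay.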